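The compounds below may be only part of what the source reports. "The series", "measured", "known", "first", "only" and "open" are said of these compounds alone.

In a functional assay, with a stated time of 150 min, tested at 15 ug/mL (a higher number here means a stronger effect of the compound at the concentration tested, a lower number a weaker effect), the measured compounds are:

compound 1, `COC(=O)c1c(Nc2ccccc2)sc(C(=O)c2ccc(OC)cc2)c1C`, 28.6%
compound 2, `COC(=O)c1c(Nc2ccc(C)cc2)sc(C(=O)c2ccc(OC)cc2)c1C`, "not active" (no number reported)
compound 3, `COc1ccc(C(=O)c2sc(Nc3ccccc3)c(C(=O)O)c2C)cc1`, 36.5%

Compound 3 holds the top of the two reported numbers, but the step of a number 7.9 percentage points higher from compound 1 to compound 3 (within the scatter) lies within the scatter, so compound 3 and compound 1 cannot be told apart; compound 2 gave no number. Compound 4, `COc1ccc(C(=O)c2sc(Nc3ccc(C)cc3)c(C(=O)O)c2C)cc1`, differs from compound 3 by methyl in place of hydrogen on an aromatic carbon. For the measured compounds named here, no measured step with two numbers covers this change. Going by the values given here, the one comparison available is the same change made on compound 1: compound 1 gives 28.6% whereas compound 2 is reported as "not active" (no number reported). A drop is therefore expected in this assay. Compound 4 is estimated at 10%, between 0% and 30%, a step of a number 26.5 percentage points lower from compound 3 to compound 4 (beyond the scatter), with a real chance that only inactivity is reported.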

Compound 4, a percentage reported as activity, at one concentration (the size of the read-out at that concentration, not a potency): "not active" (no number reported)
The entry for compound 4 holds no number, so the estimate cannot be set against anything.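

No new step can be read from compound 3 to compound 4, as compound 4 has no number in this assay to compare. On these data alone, how large the change from phenyl to 4-methylphenyl is remains open, since neither compound 2 nor compound 4 has a number. Nothing shown bears on this result.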